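This account rests on a few compounds, and the source may have more. Where it says the series, first, only, none or still open, it means among the compounds named here.

Compound 1 has the structure `N=C(S)CCCn1nc(-c2ccccc2)ccc1=O` and compound 2 has the structure `Cc1ccc(=O)n(CCCCCC(=N)S)n1`. In a functional assay on the whole organism (stomach) with Rattus norvegicus as the target (a higher number here means that more compound is needed for the effect, a lower number that less compound is needed), compound 1 gives 31.9 mg/kg. For compound 2 this assay reports only a limit, > 100 mg/kg, and no number. Where compound 2 stands is therefore known only as the limit of > 100 mg/kg in this assay, at which 1 of the 2 values shown sits, so its true dose is open. Compound 3, with the structure `N=C(S)CCCCCn1nc(-c2ccccc2)ccc1=O`, differs from compound 2 by phenyl in place of methyl on an aromatic carbon. Going by the values given here, no measured pair here shows this change on its own, so the size of the step from compound 2 to compound 3 in this assay cannot be read off directly. Compound 1, which also carries the phenyl, does give a number, but it differs from compound 3 in the length of the chain as well, so it serves only as a rough pointer. In this assay a step toward a lower dose, beyond the scatter, is expected, an at least 2.0-fold lower number from compound 2 to compound 3 (0.30 log units; that floor lies within the scatter). Compound 3 is estimated at 50 mg/kg, with a range from 20 mg/kg to 150 mg/kg.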

Compound 3, dose for half-maximal effect: 23.3 mg/kg
Compound 3: middle estimate off by 2.1-fold (0.33 log units), on the high side, and the stated range covers the measured number.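

In this assay, going by these compounds alone, phenyl in place of methyl on an aromatic carbon gives an at least 4.2-fold lower number from compound 2 to compound 3 (0.63 log units; beyond the scatter), the first direct reading of this change at this position, and it points to a clear drop in the dose needed once phenyl replaces the small methyl group. Compound 2 has only a limit, not a number, so this step gives a minimum and its true size stays unknown: the limit of > 100 mg/kg in this assay, at which 1 of the 3 values shown sits.

With phenyl held in place, the other step, a 1.4-fold lower number from compound 1 to compound 3 (0.14 log units; within the scatter), compares a group of 5 heavy atoms with a group of 3 heavy atoms on the saturated chain and shows that this difference in chain length does not separate the two compounds in this assay, which suggests that, for these two chains, the group on the aromatic carbon matters more than the chain.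

On these data alone, whether the drop calls for an aromatic ring at this position or only for a larger group remains open, and a cyclohexyl or ethyl group there would help to separate the two. Also open, as far as these compounds go, is how a chlorophenyl group at this position or a still longer chain would behave in this assay.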